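The source may report more compounds than this note shows. Statements on the series, on what has been measured and on what is new or still open speak of the compounds shown alone.

Two compounds share one core and differ only in a single group on the outer benzene ring. Compound 1 `C=C1C[C@]23C[C@@]1(O)CC[C@@H]2c1cccc(C)c1[C@@H]3Cn1cc(-c2ccc(OC)cc2)nn1` carries a methoxy group there; in a functional assay on SW480 cells (Homo sapiens) for cytotoxicity, read by MTT assay, with a stated time of 4 days (on this read-out higher numbers stand for weaker inhibition and lower numbers for stronger inhibition), compound 1 reaches the limit of the measurement, > 20000 nM. Compound 2 `C=C1C[C@]23C[C@@]1(O)CC[C@@H]2c1cccc(C)c1[C@@H]3Cn1cc(-c2ccc(F)cc2)nn1` carries a fluoro group instead; in this assay compound 2 likewise stops at the limit, > 20000 nM. The step that the two limits leave unreadable from compound 1 to compound 2 therefore cannot be sized, because of the limit of > 20000 nM in this assay, at which 2 of the 2 values shown sit. So compound 2 stands at the limit, with no number beneath it. Compound 3 `C=C1C[C@]23C[C@@]1(O)CC[C@@H]2c1cccc(C)c1[C@@H]3Cn1cc(-c2ccc(C(F)(F)F)cc2)nn1` is the next member: trifluoromethyl in place of fluoro on an aromatic carbon. Within the data shown here, the one measured step offers no guide for this change, since both of its ends are limits, and the shared core has given no readable number anywhere. The expectation is therefore that compound 3 also falls at or past the limit, with the step that the limit leaves unreadable from compound 2 to compound 3 expected to be no more than a shift between two limits. The estimate for compound 3 in this assay is 30000 nM, expected between 10000 nM and 100000 nM.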

Compound 3, half-maximal inhibitory concentration: > 20000 nM
Compound 3 gave a limit, no number; the forecaster's own chance of this, stated with the estimate: 85%; the middle value is on the limit's open side.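

Compound 3 joins compound 1 and compound 2 at a limit in this assay rather than at a number, so no step among these three compounds can be read: the limit of > 20000 nM in this assay, at which 3 of the 3 values shown sit.

The compounds shown leave open how these three rank against one another, and whether any other group at this place would give a measurable value in this assay.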